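Methyl on the pyridine-like ring of compound 1: second position

This account rests on a few compounds, and the source may have more. Where it says the series, first, only, none or still open, it means among the compounds named here.

Measured so far in a functional assay on A-375 cells (Homo sapiens) for cytotoxicity, read by MTT assay, with a stated time of 72 h, tested at 10 uM; a higher number here means more inhibition of growth at the concentration tested, a lower number less inhibition of growth:
compound 1 `N/C(=N\NC(=S)N1CCOCC1)c1ccccn1` gives 18.3%
compound 2 `Cc1ccnc(/C(N)=N/NC(=S)N2CCOCC2)c1` gives 86%
compound 3 `N/C(=N\NC(=S)N1CCCCC1)c1ccccn1` gives 85.8%

Compound 1 has the lowest of the three numbers in this assay. The other two compounds both lie far above it: the step of a number 67.7 percentage points higher from compound 1 to compound 2 (beyond the scatter) and the step of a number 67.5 percentage points higher from compound 1 to compound 3 (beyond the scatter) are each beyond the scatter and of similar size, so compound 2 and compound 3 cannot be ordered against each other.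

Compound 4 `Cc1cccc(/C(N)=N/NC(=S)N2CCOCC2)n1` has not yet been measured. It differs from compound 1 by methyl in place of hydrogen on an aromatic carbon; the methyl sits on the six-membered aromatic ring with one nitrogen, next to the ring nitrogen and meta to the large group. The step from compound 1 to compound 2 also adds a methyl to this ring, though at a different place, and it was large and upward. Going by the values given here, no measured step shows a methyl at the place used in compound 4, so the direction is taken from compound 2 while the size stays uncertain.

Compound 4 is therefore expected to show a large rise, a number 46.7 percentage points higher from compound 1 to compound 4 (beyond the scatter), because of the step of a number 67.7 percentage points higher from compound 1 to compound 2 (beyond the scatter). The estimate for compound 4 is 65%, with a range from 25% to 92%.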

Compound 4, percent growth inhibition at one concentration: 43.6%
Estimate against measurement, compound 4: 21.4 percentage points above; the measured number falls inside the stated range.
By their numbers in this assay, from the lowest: compound 1; then compound 4; then compounds 3 and 2 (each within the scatter of the next).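

In this assay a methyl next to the ring nitrogen also moves the number upward, with a number 25.3 percentage points higher from compound 1 to compound 4 (beyond the scatter) as its step, so a rise on adding methyl to this ring is not limited to the place used in compound 2. The place still counts, as the same exchange of hydrogen for methyl leaves compound 4 at 43.6% and compound 2 at 86% in this assay. No measurement at hand explains why these two places give different numbers.

Still open, as far as these compounds go, is how a longer chain such as ethyl, an amine or a chlorine atom would compare with methyl at this place. Also open, from the compounds shown here alone, is what the same methyl does when piperidin-1-yl replaces morpholin-4-yl, the other change that raised the number from compound 1.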